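The source may report more compounds than this note shows. Statements on the series, on what has been measured and on what is new or still open speak of the compounds shown alone.

Within the data shown here, in a functional assay on SK-MEL-2 cells (Homo sapiens) for cytotoxicity (on this read-out higher numbers stand for weaker inhibition and lower numbers for stronger inhibition), compound 2 `O=C1NC(c2ccccc2)CN1S(=O)(=O)c1ccccc1` gives 116000 nM and holds the only exact number so far. Compound 1 `Cc1ccc(S(=O)(=O)N2CC(c3ccc(Br)cc3)NC2=O)cc1` reads > 253000 nM as a limit of the assay, not a number. Compound 3 `Cc1ccc(S(=O)(=O)N2CC(c3ccccc3)NC2=O)cc1` awaits measurement; it differs from compound 2 by methyl in place of hydrogen on an aromatic carbon, para to a large group, turning phenyl into 4-methylphenyl (methyl in place of hydrogen on an aromatic carbon). Among the measured compounds shown here, no measured pair shows this change alone, so the expected step in this assay stays within the usual scatter, with no favoured direction. The estimated move is a 1.1-fold higher number from compound 2 to compound 3 (0.05 log units; within the scatter) and no more. For compound 3 the estimated value is 130000 nM with an expected range from 50000 nM to 320000 nM in this measurement.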

Compound 3, half-maximal inhibitory concentration: 2530 nM
Compound 3: the middle estimate sits 51-fold (1.71 log units) above what was measured, outside the stated range (below it).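

In this assay methyl in place of hydrogen on this aromatic carbon, turning phenyl into 4-methylphenyl, gives a 46-fold lower number from compound 2 to compound 3 (1.66 log units; beyond the scatter) and shows that this position is far from indifferent to the change. Hydrogen in place of bromo on an aromatic carbon gives an at least 100-fold lower number from compound 1 to compound 3 (2.00 log units; beyond the scatter) on the same read-out. Compound 1 stands only as a limit of the assay, so that step has no exact size: the limit of > 253000 nM in this assay, at which 1 of the 3 values shown sits.

As far as these compounds go, whether ethyl, methoxy or chloro in the same place would act as methyl does stays open. A single step at this position cannot show a trend.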